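Removing the alkyne linker: a furan directly on the core

A few compounds are considered here, and "the series" means these few. Any claim that something is new, unique, unknown or untested is made for them only; others in the source may bear on it.

Compound 1 `Nc1ncnn2c([C@@H]3O[C@H](CO)[C@@H](O)[C@H]3O)cc(C#Cc3cccs3)c12`: 26600 nM
Compound 2 `Nc1ncnn2c([C@@H]3O[C@H](CO)[C@@H](O)[C@H]3O)cc(C#Cc3ccccc3)c12`: 38500 nM

In a functional assay on NCI-H460 cells (Homo sapiens) for antiproliferative activity, with a stated time of 72 h (a lower number here means a stronger inhibitor, a higher number a weaker inhibitor), compound 1 gives 26600 nM and compound 2 gives 38500 nM; compound 1 has the lowest of the two numbers, and a 1.4-fold higher number from compound 1 to compound 2 (0.16 log units; within the scatter). Compound 3 `Nc1ncnn2c([C@@H]3O[C@H](CO)[C@@H](O)[C@H]3O)cc(-c3ccoc3)c12` differs from compound 1 by furan-3-yl in place of 2-(thiophen-2-yl)ethynyl on an aromatic carbon. For the measured compounds named here, the only measured step concerns a different change and lies within the scatter, so no measured step bears on this one. Compound 3 is therefore expected near compound 1, at 30000 nM (range 8000 nM to 120000 nM), a step of a 1.1-fold higher number from compound 1 to compound 3 (0.05 log units; within the scatter).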

Compound 3, half-maximal inhibitory concentration: 1500 nM
Compound 3: middle estimate off by 20-fold (1.30 log units), on the high side; the measured number lies below the stated range.
By their numbers in this assay, from the lowest: compound 3; then compounds 1 and 2 (each within the scatter of the next).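

In this assay the step of an 18-fold lower number from compound 1 to compound 3 (1.25 log units; beyond the scatter) and the step of a 26-fold lower number from compound 2 to compound 3 (1.41 log units; beyond the scatter) show that this position is sensitive to the change. Exchanging the ring at the end of the alkyne had moved the number only within the scatter, whereas furan-3-yl set directly on the aromatic carbon, without the triple bond, moves it well beyond. No evidence is at hand that accounts for this change.

Furan-3-yl and the loss of the triple bond arrive in one step, so their shares remain unseparated. As far as these compounds go, how a directly attached phenyl, thiophen-2-yl or amine would behave at this carbon also stays open.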